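Aryl change on the sulfonamide: from ethyl to methoxy

The compounds below may be only part of what the source reports. "The series", "measured", "known", "first", "only" and "open" are said of these compounds alone.

Three related sulfonamides have been measured in a functional assay on M21 cells (Homo sapiens) for antiproliferative activity, read by sulforhodamine B assay, with a stated time of 48 h; a higher number here means a weaker inhibitor, a lower number a stronger inhibitor. Compound 1 `CCCCCc1ccc(NS(=O)(=O)c2ccc(N3CCNC3=O)cc2)cc1` gives 870 nM, compound 2 `CCc1ccc(NS(=O)(=O)c2ccc(N3CCNC3=O)cc2)cc1` gives 480 nM, and compound 3 `CCCCOc1ccc(NS(=O)(=O)c2ccc(N3CCNC3=O)cc2)cc1` gives 580 nM. Compound 2 carries the lowest of the three numbers, yet its steps to the others, a 1.8-fold lower number from compound 1 to compound 2 (0.26 log units; within the scatter) and a 1.2-fold higher number from compound 2 to compound 3 (0.08 log units; within the scatter), both sit within the scatter, so no ranking can be drawn. Compound 4 `COc1cccc(NS(=O)(=O)c2ccc(N3CCNC3=O)cc2)c1` differs from compound 2 by 3-methoxyphenyl in place of 4-ethylphenyl on a sulfonamide nitrogen. The steps that touch this part of the molecule, a 1.5-fold lower number from compound 1 to compound 3 (0.18 log units; within the scatter) and a 1.2-fold higher number from compound 2 to compound 3 (0.08 log units; within the scatter), were all small, though none of them placed a methoxy group or moved the substituent. No step beyond the scatter is therefore expected in this assay. Compound 4 is estimated at 650 nM, with a range from 250 nM to 1700 nM. The expected step is a 1.4-fold higher number from compound 2 to compound 4 (0.13 log units; within the scatter).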

Compound 4, half-maximal inhibitory concentration: 65 nM
Estimate against measurement, compound 4: 10-fold (1.00 log units) above; measured number outside the range, below it.
By their numbers in this assay, from the lowest: compound 4; then compounds 2, 3 and 1 (each within the scatter of the next).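

For the compounds shown here, the aryl group on the sulfonamide nitrogen matters more in this assay than the earlier steps suggested: 3-methoxyphenyl in place of 4-ethylphenyl gives a 7.4-fold lower number from compound 2 to compound 4 (0.87 log units; beyond the scatter), the first step beyond the scatter. This single swap changes both the substituent and its place on the ring, so the two changes cannot be told apart. Nothing measured here accounts for the step.

On these data alone, whether the methoxy group or its place drives the drop remains open. A 4-methoxyphenyl or 3-ethylphenyl group could separate the two, while 3-aminophenyl would test a different substituent at that place.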